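The source may report more compounds than this note shows. Statements on the series, on what has been measured and on what is new or still open speak of the compounds shown alone.

In an ADME assay on MDCK cells (Canis lupus familiaris) for cytotoxicity, read by MTT assay, with a stated time of 24 h (on this read-out lower numbers stand for higher toxicity in this test and higher numbers for lower toxicity in this test), compound 1 (`O=[N+]([O-])c1ccc(S(=O)(=O)NCc2ccoc2)cc1`) gives > 236000 nM as a limit of the assay and not a number. Compound 2 (`O=[N+]([O-])c1ccc(S(=O)(=O)NCc2cc3ccccc3s2)cc1`) likewise stands only at a limit, > 191000 nM in this assay and no number. Among the measured compounds shown here, no step between measured compounds is available to calibrate a structural change. Compound 3 (`Cc1ccc(S(=O)(=O)NCc2cc3ccccc3s2)cc1`) departs from compound 2 through methyl in place of nitro on an aromatic carbon (methyl in place of nitro on an aromatic carbon, para to a large group). No shift beyond the usual scatter is expected in this assay and no direction is assumed. The expected step that the limit leaves unreadable from compound 2 to compound 3 is accordingly small, and a further limit rather than a number is the likely report. For compound 3 the estimated value is 200000 nM (expected range 90000 nM to 300000 nM).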

Compound 3, half-maximal cytotoxic concentration: > 210000 nM
Compound 3: no number, only a limit (the forecaster's own chance of this, stated with the estimate: 80%); at least 1.0-fold (0.02 log units) between middle value and limit.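

No step can be read in this assay between compound 2 and compound 3: each is reported only as a limit and not as a number. The compounds shown leave open whether methyl in place of nitro changes the half-maximal cytotoxic concentration at all.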